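Neopentyl Added to the Fused Ring of a Cytotoxicity Series

The compounds below may be only part of what the source reports. "The series", "measured", "known", "first", "only" and "open" are said of these compounds alone.

Compound 1 `Cc1nc(N[C@H](C)c2ccc(-c3cnn(C)c3)cc2)nc(N[C@@H]2C[C@H](CO)[C@@H](O)[C@H]2O)c1-c1nc2cnccc2s1`: 25000 nM
Compound 2 `Cc1nc(N[C@H](C)c2ccc(OC(F)(F)F)cc2)nc(N[C@@H]2C[C@H](CO)[C@@H](O)[C@H]2O)c1-c1nc2cnccc2s1`: 25000 nM

In an ADME assay on cells (Homo sapiens) for cytotoxicity, read by polymerase chain reaction, with a stated time of 3 days (a lower number here means that less compound is tolerated, a higher number that more compound is tolerated), compound 1 gives 25000 nM. Compound 2 is no change at the digits printed from compound 1 to compound 2 (within the scatter). Compound 2 thus stands level with compound 1 on these numbers, both tolerated at the same concentration.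

Compound 3 `Cc1nc(N[C@H](C)c2ccc(OC(F)(F)F)cc2)nc(N[C@@H]2C[C@H](CO)[C@@H](O)[C@H]2O)c1-c1nc2c(CC(C)(C)C)nccc2s1` differs from compound 2 by neopentyl in place of hydrogen on an aromatic carbon. Going by the values given here, no measured step touches this place on the core, so the single known step, no change at the digits printed from compound 1 to compound 2 (within the scatter), offers no direct guide. With no evidence of change in this series, compound 3 is expected to shift by a 1.3-fold lower number from compound 2 to compound 3 (0.10 log units; within the scatter), most likely within the scatter. Compound 3 is therefore estimated at 20000 nM, expected between 8000 nM and 30000 nM.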

Compound 3, half-maximal cytotoxic concentration: 10000 nM
Compound 3: the middle estimate sits 2.0-fold (0.30 log units) above what was measured; measured number inside the range.
By their numbers in this assay, from the lowest: compound 3; then compounds 1 and 2 (each within the scatter of the next).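

In this assay, neopentyl in place of hydrogen on an aromatic carbon, next to the ring nitrogen, gives a 2.5-fold lower number from compound 2 to compound 3 (0.40 log units; beyond the scatter), so less compound is tolerated. Going by these compounds alone, this is the first step beyond the scatter, whereas the earlier change gave no change at the digits printed from compound 1 to compound 2 (within the scatter). Nothing measured here accounts for the step.

As far as these compounds go, whether a methyl or an amine at this place would lower the number as neopentyl does remains open. So does whether neopentyl has the same effect with 1-methyl-1H-pyrazol-4-yl in place of trifluoromethoxy.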